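A few compounds are considered here, and "the series" means these few. Any claim that something is new, unique, unknown or untested is made for them only; others in the source may bear on it.

Measured compounds:
- compound 1 `O=C(O)c1cc(-c2cccc(COc3ccc4c(=O)n(C5CC5)sc4c3)c2)ccc1Cl` — 130 nM
- compound 2 `COc1ccc(-c2cccc(COc3ccc4c(c3)CN(C3CCCC3)C4=O)c2)cc1C(=O)O` — 170 nM
- compound 3 `O=C(O)c1cc(-c2cccc(-c3ccc4c(c3)CN(C3CCCC3)C4=O)c2)ccc1Cl` — 20 nM

In an assay on HEK293 cells for positive allosteric modulation of metabotropic glutamate receptor 2 (Rattus norvegicus), read by thallium flux (on this read-out higher numbers stand for an effect only at larger amounts of compound and lower numbers for an effect already at smaller amounts), compound 1 gives 130 nM, the second highest of the three numbers. Compound 2 gives 170 nM, which lies within the scatter of the number for compound 1. Compound 3 gives 20 nM, a lower number than compound 1 by a gap beyond the scatter.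

Compound 4 `CC(C)CCn1sc2cc(OCc3cccc(-c4ccc(Cl)c(C(=O)O)c4)c3)ccc2c1=O` is not yet measured. It differs from compound 1 in one place: isopentyl in place of cyclopropyl on an aromatic nitrogen. Among the measured compounds shown here, no measured pair shows a change of this kind, so no step size is known from the data. The expectation is a step no larger than the scatter, in either direction. For compound 4 the estimated value in this assay is 100 nM, with a range from 35 nM to 300 nM, meaning an expected step of a 1.3-fold lower number from compound 1 to compound 4 (0.11 log units; within the scatter).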

Compound 4, half-maximal effective concentration: 650 nM
For compound 4 the middle estimate is 6.5-fold (0.81 log units) below the measured one; measured number above the stated range.
By their numbers in this assay, from the lowest: compound 3; then compounds 1 and 2 (each within the scatter of the next); then compound 4.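

The substituent on the aromatic nitrogen, next to the ring sulfur, matters: in this assay, isopentyl in place of cyclopropyl gives a 5.0-fold higher number from compound 1 to compound 4 (0.70 log units; beyond the scatter), the first step read at this place in the series. This single step changes both the ring and the chain, so the two contributions cannot be separated. No evidence on hand explains the step.

Open, going by these compounds, is whether ring loss or carbon count drives the step. An ethyl chain or a cyclohexyl ring on this nitrogen would help separate the two.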